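The source may hold more compounds than are shown below. What is called first, only, known or untested is meant among the compounds shown, and "the series" means these compounds.

Measured compounds:
Compound 1 `CCCC(=O)O[C@H]1C(=O)OCC1(C)C`, in an assay on isolated protein for inhibition of fatty acid synthase (Mus musculus), read by spectrophotometry, using NADPH, with stated times of 30 min and 3 min, in the presence of a further agent that is not named here (on this read-out lower numbers stand for stronger inhibition and higher numbers for weaker inhibition), compound 1 gives 28200 nM.
Compound 2 `CCCCCC(=O)O[C@H]1C(=O)OCC1(C)C`, in this assay compound 2 gives 23300 nM.
Compound 3 `CC1(C)COC(=O)[C@@H]1OC(=O)c1ccc(Cl)cc1`, in this assay compound 3 gives 19200 nM.

Compound 3 gives the lowest of the three numbers, yet its gap to compound 2 and to compound 1 stays within the scatter, so no order among the three can be claimed. Compound 4 `CCCCc1ccc(C(=O)O[C@H]2C(=O)OCC2(C)C)cc1` differs from compound 3 by butyl in place of chloro on an aromatic carbon. Among the compounds with values here, the only measured step that bears on it is the chain lengthening a 1.2-fold lower number from compound 1 to compound 2 (0.08 log units; within the scatter), which did not move the read-out beyond the scatter. On that basis, the step of a 1.3-fold lower number from compound 3 to compound 4 (0.11 log units; within the scatter) is expected to be small. Compound 4 is therefore estimated at 15000 nM, with a range from 5000 nM to 45000 nM.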

Compound 4, half-maximal inhibitory concentration: 27700 nM
Compound 4: middle estimate off by 1.8-fold (0.27 log units), on the low side; the range from low to high includes it.
By their numbers in this assay, from the lowest: compounds 3, 2, 4 and 1 (each within the scatter of the next).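

On an aromatic carbon para to a large group, butyl in place of chloro gives a 1.4-fold higher number from compound 3 to compound 4 (0.16 log units; within the scatter) in this assay and so stays within the scatter. Where the earlier step concerned only a saturated chain, this one shows that exchanging a single chlorine for four carbons at this aromatic position produces no readable difference. Nothing available accounts for this result. Going by these compounds, whether an amine or a carboxylic acid on this carbon would move the number beyond the scatter remains open. So does the question of which part of these compounds governs the read-out at all.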